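The source may hold more compounds than are shown below. What is called first, only, known or untested is meant among the compounds shown, and "the series" means these compounds.

Working notes, series read in a functional assay on HCT-116 cells (Homo sapiens) for antiproliferative activity, read by MTT assay, with a stated time of 72 h; on this read-out lower numbers stand for stronger inhibition and higher numbers for weaker inhibition:

- compound 1 `O=C(O)CCCCCOc1ccc2cc1COC/C=C/COCc1cccc(c1)-c1ccnc(n1)N2`: 41000 nM
- compound 2 `O=C(NO)c1cccc(NCCOc2ccc3cc2COC/C=C/COCc2cccc(c2)-c2ccnc(n2)N3)c1`: 2010 nM
- compound 3 `O=C(CCCCCOc1ccc2cc1COC/C=C/COCc1cccc(c1)-c1ccnc(n1)N2)NO`: 2560 nM

Compound 3 stands second highest of the three numbers, but its place relative to compound 2 is not resolved: a 1.3-fold higher number from compound 2 to compound 3 (0.11 log units; within the scatter). It lies well clear of compound 1: a 16-fold lower number from compound 1 to compound 3 (1.20 log units; beyond the scatter).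

The next entry is compound 4 `O=C(O)CCCCCCCOc1ccc2cc1COC/C=C/COCc1cccc(c1)-c1ccnc(n1)N2`, still unmeasured. The change is 2-carboxyethyl in place of hydroxycarbamoyl on a saturated chain carbon, five bonds along the chain from an oxygen on an aromatic ring, so 2-carboxyethyl replaces hydroxycarbamoyl, on a saturated chain carbon, five bonds along the chain from an oxygen on an aromatic ring.

The large step from hydroxy to hydroxyamino on a carbonyl carbon bears most directly, and the change to compound 4 runs the opposite way, ending in a carboxy group. The step of a 20-fold lower number from compound 1 to compound 2 (1.31 log units; beyond the scatter) is also large. Going by the values given here, no measured step isolates chain length. A large move to a higher number is therefore expected in this assay.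

The expected step is a 12-fold higher number from compound 3 to compound 4 (1.07 log units; beyond the scatter).

The estimate for compound 4 is 30000 nM, with an expected range of 10000 nM to 90000 nM.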

Compound 4, half-maximal inhibitory concentration: 8040 nM
The estimate for compound 4 lay 3.7-fold (0.57 log units) above the measured number, outside the stated range (below it).
By their numbers in this assay, from the lowest: compounds 2 and 3 (each within the scatter of the next); then compound 4; then compound 1.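

In this assay, going by these compounds alone, a carboxy end does not by itself give a number as high as that of compound 1 once the chain is longer: the change shows a 5.1-fold lower number from compound 1 to compound 4 (0.71 log units; beyond the scatter), the first reading on chain length, while the two hydroxycarbamoyl compounds remain modestly lower, with a 3.1-fold higher number from compound 3 to compound 4 (0.50 log units; beyond the scatter) and a 4.0-fold higher number from compound 2 to compound 4 (0.60 log units; beyond the scatter). Placing 2-carboxyethyl in place of hydroxycarbamoyl on this saturated chain carbon therefore gives a smaller step than the large one seen on the shorter chain, a 16-fold lower number from compound 1 to compound 3 (1.20 log units; beyond the scatter), although the new step changes end group and chain length together. Nothing available accounts for this difference in step size.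

The compounds shown leave open how a hydroxycarbamoyl group would read on the chain length of compound 4, so the contributions of chain length and end group remain unseparated. Also open, as far as these compounds go, is whether a still longer chain ending in a carboxylic acid, or a chain ending in an amine, would continue this trend.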